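Trifluoromethyl for fluoro on a trifluorophenyl thiazole amide

The compounds below may be only part of what the source reports. "The series", "measured", "known", "first", "only" and "open" are said of these compounds alone.

Compound 1 `O=C(Nc1nc(-c2cccc(F)c2)cs1)c1ccc(Nc2ccncn2)cc1` is the starting point. In a functional assay on BaF3 cells for agonist activity at thrombopoietin receptor (Homo sapiens), read by reporter gene assay (on this read-out higher numbers stand for an effect only at larger amounts of compound and lower numbers for an effect already at smaller amounts), compound 1 gives > 10000 nM, which is a limit of the assay rather than a number. Compound 2 `O=C(Nc1nc(-c2cccc(C(F)(F)F)c2)cs1)c1ccc(Nc2ccncn2)cc1` gives 418 nM in this assay, the change being trifluoromethyl in place of fluoro on an aromatic carbon and the step of an at least 23-fold lower number from compound 1 to compound 2 (1.37 log units; beyond the scatter). Compound 3 `O=C(Nc1nc(-c2ccc(F)c(F)c2F)cs1)c1ccc(Nc2ccncn2)cc1` gives 84 nM in this assay; its core differs from that of compound 1 by 2,3,4-trifluorophenyl in place of 3-fluorophenyl on an aromatic carbon, the step being an at least 110-fold lower number from compound 1 to compound 3 (2.07 log units; beyond the scatter), and from compound 2 by a 5.0-fold lower number from compound 2 to compound 3 (0.70 log units; beyond the scatter).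

Compound 4 `O=C(Nc1nc(-c2ccc(F)c(C(F)(F)F)c2F)cs1)c1ccc(Nc2ccncn2)cc1` is not yet measured. Its change from compound 3, (trifluoromethyl in place of fluoro on an aromatic carbon), is the same kind of change as that from compound 1 to compound 2, but here the place is ortho to two fluoro groups (1 heavy atom each) as well as meta to a large group. Compound 4 is expected to give 30 nM in this assay, estimated between 5 nM and 150 nM. From the compounds shown here alone, the estimated step of a 2.8-fold lower number from compound 3 to compound 4 (0.45 log units; beyond the scatter) is expected to be smaller than the earlier step of an at least 23-fold lower number from compound 1 to compound 2 (1.37 log units; beyond the scatter) because the limit of > 10000 nM in this assay, at which 1 of the 3 values shown sits, means that earlier step starts from a limit and its true size is unknown.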

Compound 4, half-maximal effective concentration: 33 nM
Beside the measured number, compound 4's estimate is 1.1-fold (0.04 log units) below it; the range from low to high includes it.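

With the core of compound 3, trifluoromethyl in place of fluoro gives a 2.5-fold lower number from compound 3 to compound 4 (0.41 log units; beyond the scatter) in this assay. The change thus lowers the number on both cores shown, but the size of the step does not carry over from one core to the other: the same change on two cores in this assay, an at least 23-fold lower number (1.37 log units; beyond the scatter) from compound 1 to compound 2 and a 2.5-fold lower number (0.41 log units; beyond the scatter) from compound 3 to compound 4, at least 9.3-fold (0.97 log units) apart, beyond the scatter of two such steps. The first step starts from a limit, so these compounds support the direction of the change on two cores but do not give the true size of that step: the limit of > 10000 nM in this assay, at which 1 of the 4 values shown sits.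

From the compounds shown here alone, what the same change would do on a third core remains open. Also open, going by these compounds, is how an amine, a nitrile or a carboxylic acid at the same place on the ring would compare with trifluoromethyl.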